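The compounds below may be only part of what the source reports. "The series", "measured", "known", "first", "only" and "open" are said of these compounds alone.

Measured compounds, all in a functional assay on HeLa cells (Homo sapiens) for antiproliferative activity, read by MTT assay, with a stated time of 48 h; a lower number here means a stronger inhibitor, a higher number a weaker inhibitor:

compound 1, `CCNCC(=O)Nc1cc(OC)ccc1C(=O)c1cc(OC)c(OC)c(OC)c1`, gives 2100 nM
compound 2, `COc1ccc(C(=O)c2cc(OC)c(OC)c(OC)c2)c(NC(=O)CN(C)C)c1`, gives 470 nM
compound 3, `C=C(c1ccc2c(c1)C=CC(C)(C)O2)c1ccc(OC)cc1NC(=O)CNCC`, gives 1580 nM

Compounds 1 and 2 share one core and differ in a single place: dimethylamino in place of ethylamino on a saturated chain carbon bound to a carbonyl carbon. That change gave a 4.5-fold lower number from compound 1 to compound 2 (0.65 log units; beyond the scatter), so within this pair the dimethylamino compound is the stronger inhibitor in this assay.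

Compound 3 carries a different core, and how it differs from the core of compound 1 is not broken down here. Its value sits close to that of compound 1 and well apart from that of compound 2.

Compound 4, `C=C(c1ccc2c(c1)C=CC(C)(C)O2)c1ccc(OC)cc1NC(=O)CN(C)C`, is not yet measured. It differs from compound 3 in exactly one place: dimethylamino in place of ethylamino on a saturated chain carbon bound to a carbonyl carbon. For the measured compounds named here, this is the same change as the one made from compound 1 to compound 2, at the same place, so the step from compound 1 to compound 2 is the only direct guide to what compound 4 may do in this assay.

Going by the values given here, the expectation for compound 4 rests on a single precedent on another core, so it is held with some caution: a step of about a 4.0-fold lower number from compound 3 to compound 4 (0.60 log units; beyond the scatter) is expected, a little less confident than the one seen from compound 1 to compound 2 because a 4.5-fold lower number from compound 1 to compound 2 (0.65 log units; beyond the scatter) is the only measured example. On that basis compound 4 is estimated at 400 nM in this assay, with a plausible range from 150 nM to 1100 nM.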

Compound 4, half-maximal inhibitory concentration: 640 nM
Beside the measured number, compound 4's estimate is 1.6-fold (0.20 log units) below it; low and high end bracket the measured number.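

In this assay, dimethylamino in place of ethylamino on a saturated chain carbon bound to a carbonyl carbon gave a 2.5-fold lower number from compound 3 to compound 4 (0.39 log units; beyond the scatter), so the direction seen on the core of compound 1 recurs on the core of compound 3. The size of the step also carries over from one core to the other as far as two pairs can tell, since the two steps cannot be told apart: the same change on two cores in this assay, a 4.5-fold lower number (0.65 log units; beyond the scatter) from compound 1 to compound 2 and a 2.5-fold lower number (0.39 log units; beyond the scatter) from compound 3 to compound 4, 1.8-fold (0.26 log units) apart, within the scatter of two such steps. For the compounds shown here, with only two pairs this is no general rule for the series, and the numbers do not show what drives the step, including whether the loss of the hydrogen-bond donor counted for ethylamino plays any part.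

The compounds shown leave open how other groups would behave at this place, such as a primary amine, diethylamino or a carboxylic acid, and whether a longer chain carrying the dimethylamino group would keep the lower number. They also leave open whether the same step would appear on a third core or in cells other than those of this assay.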